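This account rests on a few compounds, and the source may have more. Where it says the series, first, only, none or still open, it means among the compounds named here.

Measured so far:
Compound 1, `CC(C)(C)c1ccc(CN2CCN(C(=O)CCc3cc(-c4ccc(C(F)(F)F)cc4)n(-c4ccc5ccccc5n4)n3)CC2)cc1`: 3000 nM
Compound 2, `COc1ccc(-n2nc(CCC(=O)N3CCN(Cc4ccc(C(C)(C)C)cc4)CC3)cc2-c2ccc(F)cc2)nn1`: > 10000 nM

Compound 2 sits at the assay limit, (the limit of > 10000 nM in this assay, at which 1 of the 2 values shown sits), so only a bound and no number is known for it. Compound 1 gives 3000 nM in an assay on isolated protein for inhibition of Polyunsaturated fatty acid 5-lipoxygenase (Homo sapiens), read by HPLC, with a stated time of 15 min, in the presence of a further agent that is not named here; on this read-out higher numbers stand for weaker inhibition and lower numbers for stronger inhibition; its core differs from that of compound 2 in more than one place, so the two values stand side by side without a counted step between them. Compound 3, `COc1ccc(-n2nc(CCC(=O)N3CCN(Cc4ccc(C(C)(C)C)cc4)CC3)cc2-c2ccc(C(F)(F)F)cc2)nn1`, is not yet measured and differs from compound 2 by trifluoromethyl in place of fluoro on an aromatic carbon. Going by the values given here, no step between measured compounds covers this change. Starting from a limit, no step size can be fixed from the data; with the few points available, compound 3 is expected to remain weak in this assay, with any gain likely small and possibly within the scatter. The estimate for compound 3 is 8000 nM (range 2500 nM to 30000 nM), which corresponds to an expected step of an at least 1.2-fold lower number from compound 2 to compound 3 (0.09 log units; that floor lies within the scatter).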

Compound 3, half-maximal inhibitory concentration: 8000 nM
The estimate for compound 3 equals the measured number at the digits printed; low and high end bracket the measured number.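

In this assay, the change from 4-fluorophenyl to 4-(trifluoromethyl)phenyl gives an at least 1.2-fold lower number from compound 2 to compound 3 (0.09 log units; that floor lies within the scatter), which is a floor and not a measured size. Compound 2 has a limit and not a number: the limit of > 10000 nM in this assay, at which 1 of the 3 values shown sits.

With 4-(trifluoromethyl)phenyl held fixed, the group on the aromatic nitrogen can now be compared in a single change: 6-methoxypyridazin-3-yl in place of quinolin-2-yl gives a 2.7-fold higher number from compound 1 to compound 3 (0.43 log units; beyond the scatter).

As far as these compounds go, whether trifluoromethyl truly lowers the number stays open while the fluoro partner has only a limit, and this single pair cannot show whether quinolin-2-yl would also give the lower number alongside 4-fluorophenyl. From the compounds shown here alone, how a carboxylic acid or an amine in place of trifluoromethyl would read in this assay also remains open.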